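A few compounds are considered here, and "the series" means these few. Any claim that something is new, unique, unknown or untested is made for them only; others in the source may bear on it.

Measured so far:
compound 1 `CN(C)CCn1c(=O)c(=Cc2ccc(F)cc2F)s/c1=C1\C(=O)Nc2cc(F)ccc21` gives 3200 nM
compound 2 `COc1ccc(C=c2s/c(=C3\C(=O)Nc4cc(F)ccc43)n(CCN(C)C)c2=O)cc1` gives 2200 nM
compound 3 `CN(C)CCn1c(=O)c(=Cc2ccc(C=O)c(C=O)c2)s/c1=C1\C(=O)Nc2cc(F)ccc21` gives 2810 nM

All three share one core and differ only in the aryl group on a double-bonded chain carbon bound to an aromatic carbon. In a functional assay on NCI-H460 cells (Homo sapiens) for inhibition, read by MTT assay, with a stated time of 72 h (on this read-out higher numbers stand for weaker inhibition and lower numbers for stronger inhibition), compound 3 stands apart from neither neighbour: the step of a 1.1-fold lower number from compound 1 to compound 3 (0.06 log units; within the scatter) and the step of a 1.3-fold higher number from compound 2 to compound 3 (0.11 log units; within the scatter) both lie within the scatter, so the three numbers cannot be told apart.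

Compound 4 `COc1ccc(OC)c(C=c2s/c(=C3\C(=O)Nc4cc(F)ccc43)n(CCN(C)C)c2=O)c1` is not yet measured. Its change from compound 3 is 2,5-dimethoxyphenyl in place of 3,4-diformylphenyl on a double-bonded chain carbon bound to an aromatic carbon. Among the measured compounds shown here, the steps that bear on it, a 1.5-fold lower number from compound 1 to compound 2 (0.16 log units; within the scatter) and a 1.3-fold higher number from compound 2 to compound 3 (0.11 log units; within the scatter), swapped aryl groups at the same place without moving the number beyond the scatter. An estimated step of a 1.1-fold lower number from compound 3 to compound 4 (0.05 log units; within the scatter) is therefore expected, none beyond the scatter. Compound 4 is estimated at 2500 nM, likely between 1200 nM and 5500 nM.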

Compound 4, half-maximal inhibitory concentration: 7150 nM
The estimate for compound 4 lay 2.9-fold (0.46 log units) below the measured number; measured number outside the range, above it.
By their numbers in this assay, from the lowest: compounds 2, 3 and 1 (each within the scatter of the next); then compound 4.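

In this assay, this position proves sensitive to the choice of aryl group: 2,5-dimethoxyphenyl on the double-bonded chain carbon moves the number beyond the scatter against every earlier compound (a 2.5-fold higher number from compound 3 to compound 4 (0.41 log units; beyond the scatter); a 3.3-fold higher number from compound 2 to compound 4 (0.51 log units; beyond the scatter); a 2.2-fold higher number from compound 1 to compound 4 (0.35 log units; beyond the scatter)). The group that leaves and the group that enters have equal heavy-atom and hydrogen-bond acceptor counts, so those counts do not separate compound 3 from compound 4. No measurement available here explains the rise.

Still open, on these data alone, is whether a single methoxy group at another ring position would give the same rise. As far as these compounds go, how an aryl group bearing a carboxylic acid would read at this place is also open.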